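The source may hold more compounds than are shown below. What is called first, only, known or untested is meant among the compounds shown, and "the series" means these compounds.

Measured compounds and their values:

Compound 1, `c1ccc(-c2nnc(-c3c[nH]c4ccccc34)o2)cc1`: in a functional assay on MIA PaCa-2 cells (Homo sapiens) for cytotoxicity, read by MTT assay (a lower number here means a stronger inhibitor, a higher number a weaker inhibitor), compound 1 reaches only the assay limit, > 1000000 nM.
Compound 2, `c1ccc2c(-c3nnc(-c4ccncc4)o3)c[nH]c2c1`: in this assay compound 2 gives 1600 nM.
Compound 3, `c1cncc(-c2nnc(-c3c[nH]c4ccccc34)o2)c1`: in this assay compound 3 gives 900 nM.

Compound 3 holds the lowest of the two numbers seen so far; compound 2 sits nearest, and the gap between them, a 1.8-fold lower number from compound 2 to compound 3 (0.25 log units; within the scatter), stays within the scatter. The remaining value, that of compound 1, is a limit only (the limit of > 1000000 nM in this assay, at which 1 of the 3 values shown sits), so compound 1 cannot be ranked against the others beyond that.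

Compound 4, `FC(F)(F)c1nnc(-c2c[nH]c3ccccc23)o1`, is not yet measured. Its difference from compound 3 is trifluoromethyl in place of pyridin-3-yl on an aromatic carbon. The measured steps that bear on this are those that removed the pyridyl nitrogen from the pendant ring: an at least 620-fold lower number from compound 1 to compound 2 (2.79 log units; beyond the scatter) and an at least 1100-fold lower number from compound 1 to compound 3 (3.04 log units; beyond the scatter), both large and beyond the scatter, where a group with one hydrogen-bond acceptor entered in place of one with none. Trifluoromethyl, like phenyl, carries no hydrogen-bond acceptor, so a large rise in the number is expected in this assay, though no step with a non-ring group has been measured and the size is uncertain. For compound 4 the expected step is a 67-fold higher number from compound 3 to compound 4 (1.82 log units; beyond the scatter). Compound 4 is estimated at 60000 nM, within 5000 nM to 1000000 nM.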

Compound 4, half-maximal inhibitory concentration: > 1000000 nM
Compound 4 was reported as a limit; the forecaster's own chance of this, stated with the estimate: 35%; middle value at least 16-fold (1.22 log units) away from the limit.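

In this assay, trifluoromethyl at this carbon of the five-membered ring gives an at least 1100-fold higher number from compound 3 to compound 4 (3.04 log units; beyond the scatter) and an at least 620-fold higher number from compound 2 to compound 4 (2.79 log units; beyond the scatter), so both of these steps are large. Replacing the pendant ring with a non-ring group therefore does not give a readable value, and among the four compounds only the two pyridyl compounds, compound 2 and compound 3, stand clear of the assay limit. The step between compound 1 and compound 4 cannot be read, because both values are limits: the limit of > 1000000 nM in this assay, at which 2 of the 4 values shown sit.

From the compounds shown here alone, it remains open whether the ring nitrogen of the pyridyl groups is sufficient without the ring, which a non-ring group such as an amine, a nitrile or a carboxylic acid at this carbon would test. Pyridin-2-yl also remains open, as does any substituted pyridine.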